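Squaramide series: branched alkyl exchange on the imine nitrogen

The compounds below may be only part of what the source reports. "The series", "measured", "known", "first", "only" and "open" are said of these compounds alone.

Measured so far in a functional assay for inhibition, with Rattus norvegicus as the target; a higher number here means a weaker inhibitor, a lower number a stronger inhibitor:
compound 1 `CC(C)C/N=c1\c(O)c(O)\c1=N/Cc1ccc(C#N)cc1`, 10200 nM;
compound 2 `CC(C)(C)/N=c1\c(O)c(O)\c1=N/Cc1ccccn1`, 11500 nM;
compound 3 `Cc1cc(Cl)cc(Cl)c1C/N=c1\c(O)c(O)\c1=N/C(C)C(C)(C)C`, 9800 nM.

Compound 1 holds the second highest of the three numbers in this assay; its nearest neighbour is compound 3 and its furthest is compound 2, and both gaps fall within the scatter, so the three values cannot be told apart. Compound 4 `CCC(C)(C)/N=c1\c(O)c(O)\c1=N/Cc1ccc(C#N)cc1` differs from compound 1 in one place: 1,1-dimethylpropyl in place of isobutyl on a double-bonded nitrogen. For the measured compounds named here, no step between measured compounds involves this exchange. Because the three numbers, among them 10200 nM for compound 1, sit so close, the step of a 1.0-fold lower number from compound 1 to compound 4 (0.01 log units; within the scatter) is expected to stay within the scatter. Compound 4 is estimated at 10000 nM, ranging from 5000 nM to 20000 nM.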

Compound 4, half-maximal inhibitory concentration: 1100 nM
The estimate for compound 4 lay 9.1-fold (0.96 log units) above the measured number; measured number below the stated range.
By their numbers in this assay, from the lowest: compound 4; then compounds 3, 1 and 2 (each within the scatter of the next).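

In this assay, 1,1-dimethylpropyl in place of isobutyl on a double-bonded nitrogen gives a 9.3-fold lower number from compound 1 to compound 4 (0.97 log units; beyond the scatter), so this position can move the number well beyond the scatter, which the three earlier values, all within the scatter of one another, did not reveal. The two groups differ by a single carbon, yet the step is large. Nothing available accounts for the step.

From the compounds shown here alone, whether a longer chain such as 1,1-dimethylbutyl, or a cyclopentyl group, keeps the lower number remains open. Also open, going by these compounds, is whether the same exchange holds in compounds without the nitrile.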